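The source may hold more compounds than are shown below. What is called first, only, known or untested is meant among the compounds shown, and "the series" means these compounds.

Measured compounds in a functional assay on UACC-257 cells (Homo sapiens) for cytotoxicity, read by sulforhodamine B assay, with a stated time of 48 h; a higher number here means a weaker inhibitor of growth, a lower number a stronger inhibitor of growth:
compound 1 `ClCc1ccc(Cn2cnc3c(Cl)ncnc32)cc1` gives 28800 nM; compound 2 `ClCc1ccc(Cn2cnc3nc(Cl)nc(Cl)c32)cc1` gives 5490 nM; compound 3 `ClCc1ccc(Cn2cnc3c(Cl)nc(Cl)nc32)cc1` gives 33100 nM.

Compound 2 stands lowest of the three numbers in this assay, beyond the scatter from both compound 1 and compound 3. Compound 4 `ClCc1ccc(Cn2cnc3ncnc(Cl)c32)cc1` differs from compound 2 by hydrogen in place of chloro on an aromatic carbon. The only measured step that bears on this change is the reverse one in the other series, a 1.1-fold higher number from compound 1 to compound 3 (0.06 log units; within the scatter), which lay within the scatter. On that basis the removal of the chloro between the two ring nitrogens is expected to leave the number close to that of compound 2, with at most a small rise. Compound 4 is therefore estimated at 7000 nM, within 2500 nM to 20000 nM, a step of a 1.3-fold higher number from compound 2 to compound 4 (0.11 log units; within the scatter).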

Compound 4, concentration for total growth inhibition: 3460 nM
Beside the measured number, compound 4's estimate is 2.0-fold (0.31 log units) above it; measured number inside the range.
By their numbers in this assay, from the lowest: compounds 4 and 2 (each within the scatter of the next); then compounds 1 and 3 (each within the scatter of the next).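

In this assay, hydrogen in place of chloro on the aromatic carbon between two ring nitrogen atoms gives a 1.6-fold lower number from compound 2 to compound 4 (0.20 log units; within the scatter), so on this core too the change does not move the number beyond the scatter. The earlier compounds shown here showed this on a single core, and it now reads alike on two: the same change on two cores in this assay, a 1.1-fold higher number (0.06 log units; within the scatter) from compound 1 to compound 3 and a 1.6-fold higher number (0.20 log units; within the scatter) from compound 4 to compound 2, 1.4-fold (0.14 log units) apart, within the scatter of two such steps.

The compounds shown carry only hydrogen or chloro at this position, so what an amine, a methoxy group or a longer chain would do there stays open. As far as these compounds go, whether the same holds in other cell lines also remains open.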